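A Sulfone Swapped for a Hydroxyl on a Saturated Chain

The source may hold more compounds than are shown below. What is called first, only, known or untested is meant among the compounds shown, and "the series" means these compounds.

Compound 2 `CCS(=O)(=O)CCCCC12CCC(c3nnc(-c4ccccc4C(F)(F)F)n3C)(CC1)CC2` is one of two molecules tested in an assay on CHO-K1 cells for inhibition of 11-beta-hydroxysteroid dehydrogenase type 2 (Mus musculus), read by scintillation proximity assay; on this read-out higher numbers stand for weaker inhibition and lower numbers for stronger inhibition. In this assay compound 2 gives only a limit, > 4000 nM. Compound 1 `Cn1c(-c2ccccc2C(F)(F)F)nnc1C12CCC(CNS(C)(=O)=O)(CC1)CC2` likewise gives only a limit in this assay, > 4000 nM. The step between them, a step that the two limits leave unreadable from compound 1 to compound 2, cannot be sized because of the limit of > 4000 nM in this assay, at which 2 of the 2 values shown sit. Compound 3 `CC(O)CCCC12CCC(c3nnc(-c4ccccc4C(F)(F)F)n3C)(CC1)CC2` differs from compound 2 by 1-hydroxyethyl in place of (ethylsulfonyl)methyl on a saturated chain carbon, three bonds along the chain from a saturated ring carbon. For the measured compounds named here, no measured step reads off a direction for this change, so compound 3 is expected to stay near the limit, with the step that the limit leaves unreadable from compound 2 to compound 3 estimated as no shift beyond the scatter. Compound 3 is estimated at 6000 nM, within 1500 nM to 30000 nM.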

Compound 3, half-maximal inhibitory concentration: > 4000 nM
Compound 3: a limit, no number; the forecaster's own chance of this, stated with the estimate: 70%; the middle value lies beyond the limit too.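

No step between compound 1, compound 2 and compound 3 can be read in this assay, because each of the three gives only a limit and no number: the limit of > 4000 nM in this assay, at which 3 of the 3 values shown sit.

Going by these compounds, whether the methanesulfonamido, 3-(ethylsulfonyl)propyl or 3-hydroxybutyl group differs from the others in inhibition stays open.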